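The source may report more compounds than this note shows. Statements on the series, on what has been measured and on what is new or still open speak of the compounds shown alone.

In a functional assay on K562 cells (Homo sapiens) for cytotoxicity, read by MTT assay, with a stated time of 72 h (a higher number here means a weaker inhibitor, a lower number a stronger inhibitor), compound 2 `Cc1ccc(S(=O)(=O)n2cc(COC3=C/C(=N\c4ccc(F)cc4)c4ccccc4C3=O)nn2)cc1` gives 7700 nM, and compound 1 `Cc1ccc(S(=O)(=O)n2cc(COC3=C/C(=N\c4ccc(I)cc4)c4ccccc4C3=O)nn2)cc1` gives 10800 nM. Within the data shown here, these are the only two values so far, and they lie within the scatter of each other. Compound 3 `COc1ccc(/N=C2\C=C(OCc3cn(S(=O)(=O)c4ccc(C)cc4)nn3)C(=O)c3ccccc32)cc1` differs from compound 2 by methoxy in place of fluoro on an aromatic carbon, which is methoxy in place of fluoro on an aromatic carbon, para to a large group. Among the measured compounds shown here, the one measured step at this place is a 1.4-fold lower number from compound 1 to compound 2 (0.15 log units; within the scatter), fluoro in place of iodo, and it stays within the scatter. No step beyond the scatter is therefore expected, and the estimated step is a 1.2-fold higher number from compound 2 to compound 3 (0.07 log units; within the scatter). Compound 3 is expected at 9000 nM, with an estimated range of 3500 nM to 22000 nM.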

Compound 3, half-maximal inhibitory concentration: > 20000 nM
Compound 3 gave a limit, no number; the forecaster's own chance of this, stated with the estimate: 5%; at least 2.2-fold (0.34 log units) between middle value and limit.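

At this place on the aromatic ring, the earlier swap of one halogen for another stayed within the scatter, but methoxy in place of fluoro does not: in this assay there is an at least 2.5-fold higher number from compound 2 to compound 3 (0.41 log units; beyond the scatter). Methoxy in place of iodo gives an at least 1.8-fold higher number from compound 1 to compound 3 (0.26 log units; that floor lies within the scatter), so that comparison alone does not separate the two compounds. Compound 3 has no number here, only a limit of the assay: the limit of > 20000 nM in this assay, at which 1 of the 3 values shown sits.

As far as these compounds go, how far compound 3 lies beyond that limit remains open. So does whether an amine, a hydroxyl or a longer ethoxy chain at this place would behave like methoxy.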